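This account rests on a few compounds, and the source may have more. Where it says the series, first, only, none or still open, it means among the compounds named here.

In an assay on isolated protein with Bile acid receptor (Homo sapiens) as the target (a lower number here means that less compound is needed, a higher number that more compound is needed for the effect), compound 1 `COC(=O)/C=C/c1cccc(N(Cc2ccc(/C=C/C(=O)O)cc2)C(=O)C2CCCCC2)c1` gives 1000 nM, compound 2 `COC(=O)/C=C/c1cccc(N(Cc2ccc(/C=C/c3c(Cl)cccc3Cl)cc2)C(=O)C2CCCCC2)c1` gives 151 nM, and compound 3 `COC(=O)/C=C/c1cccc(N(Cc2ccc(-c3cc(Cl)ccc3OC)cc2)C(=O)C2CCCCC2)c1` gives 234 nM. Compound 3 thus stands second highest of the three numbers: its gap to compound 2 is within the scatter, while its gap to compound 1 is beyond it. Compound 4 `COC(=O)/C=C/c1cccc(N(Cc2ccc(-c3cccc(OC(F)(F)F)c3)cc2)C(=O)C2CCCCC2)c1` differs from compound 3 in one place: 3-(trifluoromethoxy)phenyl in place of 5-chloro-2-methoxyphenyl on an aromatic carbon. For the measured compounds named here, no measured step swaps one substituted phenyl for another; the nearest guides are a 4.3-fold lower number from compound 1 to compound 3 (0.63 log units; beyond the scatter) and a 1.5-fold higher number from compound 2 to compound 3 (0.19 log units; within the scatter), showing a modest gain when an aryl group replaces the carboxy-bearing chain, and two different aryl groups landing within the scatter of each other. The step of a 1.3-fold higher number from compound 3 to compound 4 (0.11 log units; within the scatter) is therefore expected to stay within the scatter. Compound 4 is estimated at 300 nM, with a range of 100 nM to 900 nM.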

Compound 4, half-maximal effective concentration: 417 nM
Compound 4: the middle estimate sits 1.4-fold (0.14 log units) below what was measured; low and high end bracket the measured number.
By their numbers in this assay, from the lowest: compounds 2, 3 and 4 (each within the scatter of the next, the first and the last beyond it); then compound 1.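

In this assay, exchanging one substituted phenyl for another at this place, para to a large group, gives a 1.8-fold higher number from compound 3 to compound 4 (0.25 log units; within the scatter) and so separates neither group from the other. Even so, the aryl group matters to a degree: a 2.8-fold higher number from compound 2 to compound 4 (0.44 log units; beyond the scatter) shows that 3-(trifluoromethoxy)phenyl and 2-(2,6-dichlorophenyl)ethenyl can be told apart, while a 2.4-fold lower number from compound 1 to compound 4 (0.38 log units; beyond the scatter) shows that the lower number relative to 2-carboxyethenyl persists. Nothing available explains these differences. On these data alone, whether a phenyl ring bearing an amine or a carboxylic acid at this place would lie closer to compound 1 or compound 3 remains open.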